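The compounds below may be only part of what the source reports. "The series", "measured", "known", "first", "only" and "open" are said of these compounds alone.

Measured in a physicochemical assay for solubility, read by spectrophotometry, measured as kinetic solubility, at pH 8, tested at 500 uM; a higher number here means a more soluble compound, a lower number a less soluble compound:
- compound 1 `CC(=O)N1CCCC(NC(=O)c2ccncc2Nc2cc(-c3ccc4ccn(C)c4c3)c3nccnc3c2)C1`: 212 ug/mL
- compound 2 `CN1CC(NC(=O)c2ccncc2Nc2cc(-c3ccc4ccn(C)c4c3)c3nccnc3c2)CCC1=O`: 253 ug/mL
- compound 3 `CN1CC(NC(=O)c2ccncc2Nc2cc(-c3ccc4ccn(C)c4c3)c3nccnc3c2)C1`: 170 ug/mL

These compounds share a core and differ only in the group on an amide-type nitrogen. Compound 3 stands within the scatter of the other two, with a 1.2-fold lower number from compound 1 to compound 3 (0.10 log units; within the scatter) and a 1.5-fold lower number from compound 2 to compound 3 (0.17 log units; within the scatter). The unmeasured compound 4 `CC(=O)N1CC(CNC(=O)c2ccncc2Nc2cc(-c3ccc4ccn(C)c4c3)c3nccnc3c2)C1` changes the same position: (1-acetylazetidin-3-yl)methyl in place of 1-methylazetidin-3-yl on an amide-type nitrogen. The third measured exchange, a 1.2-fold higher number from compound 1 to compound 2 (0.08 log units; within the scatter), also stayed within the scatter. Going by the values given here, no measured compound carries the (1-acetylazetidin-3-yl)methyl group, so this guide is indirect. Still, no step beyond the scatter is expected in this assay, and the expected change is a 1.2-fold higher number from compound 3 to compound 4 (0.08 log units; within the scatter). For compound 4 the estimate is 205 ug/mL, with an expected range of 120 ug/mL to 270 ug/mL.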

Compound 4, solubility: 252 ug/mL
Beside the measured number, compound 4's estimate is 1.2-fold (0.09 log units) below it; the measured number falls inside the stated range.
By their numbers in this assay, from the lowest: compounds 3, 1, 4 and 2 (each within the scatter of the next).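

In this assay, the (1-acetylazetidin-3-yl)methyl group on the amide-type nitrogen stays within the scatter of all three earlier groups (a 1.5-fold higher number from compound 3 to compound 4 (0.17 log units; within the scatter); a 1.2-fold higher number from compound 1 to compound 4 (0.08 log units; within the scatter); a 1.0-fold lower number from compound 2 to compound 4 (0.00 log units; within the scatter)). All four groups shown at this position therefore give numbers within the scatter of one another, even with the change from 5 to 8 heavy atoms on going from compound 3 to compound 4. Nothing available offers a reason for this result.

Still open, from the compounds shown here alone, is whether a carboxylic acid or a primary amine on a longer chain at this position would give a step beyond the scatter.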